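Swapping benzyl for 3-fluorophenyl on compound 3

The source may report more compounds than this note shows. Statements on the series, on what has been measured and on what is new or still open speak of the compounds shown alone.

In a functional assay on HT-29 cells (Homo sapiens) for antiproliferative activity, read by sulforhodamine B assay, with a stated time of 72 h (a higher number here means a weaker inhibitor, a lower number a stronger inhibitor), compound 1 `CN(C)C(=S)N/N=C/c1cc2cccnc2s1` gives 13400 nM. Compound 2 `NC(=S)N/N=C/c1cc2cccnc2s1` gives > 100000 nM in this assay, a limit rather than a number, namely (the limit of > 100000 nM in this assay, at which 1 of the 3 values shown sits). Going by the values given here, the step of an at least 7.4-fold higher number from compound 1 to compound 2 (0.87 log units; beyond the scatter) is the only measured change on the thiocarbonyl substituent. Compound 3 `S=C(NCc1ccccc1)N/N=C/c1ccc2ccccc2n1` gives 75700 nM in this assay, the highest of the two numbers shown; its nearest neighbour is compound 1 with a lower number. Compound 2 is known only as a limit.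

Compound 4 `Fc1cccc(NC(=S)N/N=C/c2ccc3ccccc3n2)c1` differs from compound 3 by 3-fluorophenyl in place of benzyl on an amide-type nitrogen. Among the compounds with values here, the one measured step, from compound 1 to compound 2, concerns a different substituent on the thiocarbonyl nitrogen and a different core, so it offers little guidance, and no step here compares a benzyl with a 3-fluorophenyl group. No change beyond the scatter in this assay is therefore expected for the step of a 1.3-fold lower number from compound 3 to compound 4 (0.10 log units; within the scatter). Compound 4 is expected to give about 60000 nM in this assay, within a range from 20000 nM to 200000 nM.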

Compound 4, half-maximal inhibitory concentration: 74700 nM
The estimate for compound 4 lay 1.2-fold (0.10 log units) below the measured number, within the range that was stated.
By their numbers in this assay, from the lowest: compound 1; then compounds 4 and 3 (each within the scatter of the next). At a limit, above all of these: compound 2.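

In this assay the exchange of benzyl for 3-fluorophenyl on the amide-type nitrogen gives a 1.0-fold lower number from compound 3 to compound 4 (0.01 log units; within the scatter), so at this position on this core the two groups cannot be told apart. Going by these compounds alone, this single swap both removes the carbon that links the ring to the nitrogen and adds a fluorine, and the result shows only that the two changes together leave the number within the scatter. Nothing measured here bears on a cause for this result.

Going by these compounds, whether the linking carbon and the fluorine would each leave the number unchanged on their own stays open. So does whether a different kind of group on this nitrogen, such as a longer alkyl chain, an amine or a carboxylic acid, would move the number beyond the scatter.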